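Notes on compound 4: longer chain, sulfur-bearing end

The source may report more compounds than this note shows. Statements on the series, on what has been measured and on what is new or still open speak of the compounds shown alone.

Measured so far in a functional assay on the whole organism (stomach) for inhibition, with Rattus norvegicus as the target, at a dose of 100 mg/kg by the intraduodenal route; on this read-out lower numbers stand for less inhibition and higher numbers for more inhibition at the one dose given (going by the name of the read-out):
compound 1, `N=C(S)CCN1N=C(c2cccs2)CCC1=O`: 58.5%
compound 2, `Cc1ccc(=O)n(CCC#N)n1`: 0.2%
compound 3, `Cc1ccc(=O)n(CC(=N)S)n1`: 31.5%

Compound 2 stands lowest of the three numbers; compound 3 lies beyond the scatter above it, and compound 1 further above still.

Compound 4, `Cc1ccc(=O)n(CCCCC(=N)S)n1`, is not yet measured. It differs from compound 2 as follows: a group of 5 heavy atoms (3 carbon, 1 nitrogen, 1 sulfur; no ring) in place of a group of 2 heavy atoms (1 carbon, 1 nitrogen; no ring), on a saturated chain carbon, two bonds along the chain from an aromatic nitrogen. Going by the values given here, one measured step bears on this: a number 31.3 percentage points higher from compound 2 to compound 3 (beyond the scatter), where the cyano group gave way to the sulfur-bearing group on the same chain. Among the compounds with values here, compound 4 carries the same kind of exchange but on a chain lengthened by carbon; no measured pair shows the effect of the chain length alone, so that part rests on nothing. Compound 1, with a sulfur-bearing group on its own short chain and a different core, gives 58.5%, which does not speak against such groups.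

Compound 4 is therefore expected to move upward from compound 2 by about a number 29.8 percentage points higher from compound 2 to compound 4 (beyond the scatter), with a wide range for the untested chain length. Estimated value for compound 4: 30%, between 5% and 60%.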

Compound 4, a percentage reported as inhibition, in the whole organism at one dose (the size of the read-out at that dose, not a potency): 29.5%
Estimate against measurement, compound 4: 0.5 percentage points above; the range from low to high includes it.
By their numbers in this assay, from the lowest: compound 2; then compounds 4 and 3 (each within the scatter of the next); then compound 1.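

In this assay the exchange of the cyano group for the sulfur-bearing end, here on the lengthened chain, gives a number 29.3 percentage points higher from compound 2 to compound 4 (beyond the scatter) so the gain seen earlier on the short chain is not confined to that one chain length. Going by these compounds alone, compound 3 at 31.5% and compound 4 at 29.5% lie within the scatter of each other, so at the one dose given this pair shows no readable effect of chain length on the number. Nothing on hand offers an explanation for these numbers.

From the compounds shown here alone, whether a still longer chain, or an amine or a carboxylic acid in place of the sulfur-bearing end, would hold this level stays open. Also open, going by these compounds, is how far the reading of compound 1 at 58.5% goes with its core and how far with its chain end.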